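One Methyl Removed Across Two Different Cores

The source may report more compounds than this note shows. Statements on the series, on what has been measured and on what is new or still open speak of the compounds shown alone.

In an assay on membranes from brain for binding affinity to Fatty-acid amide hydrolase 1 (Mus musculus), read by fluorescence, with stated times of 1 h and 30 min (on this read-out lower numbers stand for stronger inhibition and higher numbers for weaker inhibition), compound 1 `Cc1cnn(C(=O)N(C)CCN(C)Cc2ccc(OCc3ccccc3)cc2)c1` gives 8700 nM. Compound 2 `CN(CCN(C)C(=O)n1cccn1)Cc1ccc(OCc2ccccc2)cc1` differs from it only by hydrogen in place of methyl on an aromatic carbon; in this assay compound 2 gives 510 nM, and the step is a 17-fold lower number from compound 1 to compound 2 (1.23 log units; beyond the scatter). Compound 3 `Cc1cnn(C(=O)NCc2ccc(OC(c3ccccc3)c3ccccc3)cc2)c1` is built on another core, and the difference between the two cores is not broken down here. In this assay compound 3 reaches only a limit, > 100000 nM. That edge is the limit of > 100000 nM in this assay, at which 1 of the 3 values shown sits. Compound 4 `O=C(NCc1ccc(OC(c2ccccc2)c2ccccc2)cc1)n1cccn1` is not yet measured and stands to compound 3 as compound 2 stands to compound 1: hydrogen in place of methyl on an aromatic carbon. The place is the same word for word in both pairs, so this is the same change. For compound 4 the expected step is an at least 3.3-fold lower number from compound 3 to compound 4 (0.52 log units; beyond the scatter). That expectation rests on a 17-fold lower number from compound 1 to compound 2 (1.23 log units; beyond the scatter), tempered by the limit seen for compound 3. Compound 4 is estimated at 30000 nM.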

Compound 4, half-maximal inhibitory concentration: > 100000 nM
Compound 4 ended at the assay's limit; the forecaster's own chance of this, stated with the estimate: 40%; at least 3.3-fold (0.52 log units) between middle value and limit.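

No step from compound 3 to compound 4 can be read, because both stand at the same limit: the limit of > 100000 nM in this assay, at which 2 of the 4 values shown sit.

From the compounds shown here alone, whether going from 4-methyl-1H-pyrazol-1-yl to 1H-pyrazol-1-yl lowers the number on the core of compound 3, as it does on the core of compound 1, stays open.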